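A nitrophenyl in place of a dichlorophenyl

A few compounds are considered here, and "the series" means these few. Any claim that something is new, unique, unknown or untested is made for them only; others in the source may bear on it.

Three measured compounds share one core and differ only in what hangs from it. Compound 1 `C#CCOc1ccc(/C=C/C(C)=O)cc1OC` lacks the five-membered aromatic ring with 3 nitrogen, and in a functional assay on PC-3 cells (Homo sapiens) for antiproliferative activity, read by MTT assay, with a stated time of 48 h (a lower number here means a stronger inhibitor, a higher number a weaker inhibitor), compound 1 gives 40200 nM. Compound 2 `COc1cc(/C=C/C(C)=O)ccc1OCc1cn(-c2c(Cl)cccc2Cl)nn1` carries a 2,6-dichlorophenyl on the aromatic nitrogen of that ring, and in this assay compound 2 gives 3070 nM, the lowest number of the three, with compound 3 nearest and compound 1 furthest. Among the measured compounds shown here, compound 3 `COc1cccc(-n2cc(COc3ccc(/C=C/C(C)=O)cc3OC)nn2)c1` gives 31600 nM in this assay; the step of a 10-fold higher number from compound 2 to compound 3 (1.01 log units; beyond the scatter) is the only measured change at the same place and so the only one that bears here.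

Compound 4 `COc1cc(/C=C/C(C)=O)ccc1OCc1cn(-c2ccc([N+](=O)[O-])cc2)nn1` is not yet measured. It differs from compound 2 in that (4-nitrophenyl in place of 2,6-dichlorophenyl on an aromatic nitrogen). For the measured compounds named here, since the one comparable swap weakened inhibition by a large step, a weaker number is expected for compound 4 as well, though one precedent leaves the size uncertain. Compound 4 is estimated at 10000 nM in this assay, between 3000 nM and 40000 nM, the expected step being a 3.3-fold higher number from compound 2 to compound 4 (0.51 log units; beyond the scatter).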

Compound 4, half-maximal inhibitory concentration: 46700 nM
The estimate for compound 4 lay 4.7-fold (0.67 log units) below the measured number, outside the stated range (above it).
By their numbers in this assay, from the lowest: compound 2; then compounds 3, 1 and 4 (each within the scatter of the next).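

In this assay, 4-nitrophenyl on the aromatic nitrogen gives a 15-fold higher number from compound 2 to compound 4 (1.18 log units; beyond the scatter), so the loss seen with 3-methoxyphenyl is no longer a single case: two different replacements of 2,6-dichlorophenyl at this place each give a large step. The two replacements cannot be told apart, with a 1.5-fold higher number from compound 3 to compound 4 (0.17 log units; within the scatter), and among the three groups tried on this nitrogen only 2,6-dichlorophenyl stands apart. Nothing in the available data accounts for this difference.

The compounds shown leave open whether a plain phenyl, or a phenyl carrying a single chlorine, on this nitrogen would match compound 2 or compound 4. They also leave open how a group of another kind at this place, such as a benzyl or a simple alkyl chain, would read.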